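Swapping a benzyl hydroxamate for a cyclohexyl hydroxamate

A few compounds are considered here, and "the series" means these few. Any claim that something is new, unique, unknown or untested is made for them only; others in the source may bear on it.

Measured compounds:
- compound 1 `COc1cc2c(NCc3ccc(C(=O)NO)cc3)cc(-c3ccc(C)o3)nc2cc1OCCCN1CCCC1` gives 11 nM in an assay on isolated protein for inhibition of protein deacetylase HDAC6 (Homo sapiens), read by fluorescence, with a stated time of 30 min; on this read-out lower numbers stand for stronger inhibition and higher numbers for weaker inhibition
- compound 2 `COc1cc2c(NCC3CCC(C(=O)NO)CC3)cc(-c3ccc(C)o3)nc2cc1OCCCN1CCCC1` gives 34 nM in this assay
- compound 3 `COc1cc2c(NCC3CCN(Cc4ccc(C(=O)NO)cc4)CC3)cc(-c3ccc(C)o3)nc2cc1OCCCN1CCCC1` gives 53 nM in this assay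

Compound 3 has the highest number of the three, meaning the weakest inhibition; its number is within the scatter of compound 2 and beyond it only against compound 1. Compound 4 `COc1cc2c(NCC3CCN(C4CCC(C(=O)NO)CC4)CC3)cc(-c3ccc(C)o3)nc2cc1OCCCN1CCCC1` has not yet been measured. It differs from compound 3 in one place: 4-(hydroxycarbamoyl)cyclohexyl in place of 4-(hydroxycarbamoyl)benzyl on an amine nitrogen in a ring. Going by the values given here, the one measured step that bears on this is the step from compound 1 to compound 2, where a hydroxycarbamoyl-bearing aromatic ring was replaced by the saturated ring of the same size: a 3.1-fold higher number from compound 1 to compound 2 (0.49 log units; beyond the scatter). The change from compound 3 to compound 4 is of the same kind, so a modest rise in the number, beyond the scatter, is expected in this assay as well, so that compound 4 is estimated at 150 nM, most likely between 60 nM and 400 nM, a step of a 2.8-fold higher number from compound 3 to compound 4 (0.45 log units; beyond the scatter) that is expected.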

Compound 4, half-maximal inhibitory concentration: > 20000 nM
Compound 4 ended at the assay's limit; the forecaster's own chance of this, stated with the estimate: 3%; at least 130-fold (2.12 log units) between middle value and limit.
By their numbers in this assay, from the lowest: compound 1; then compounds 2 and 3 (each within the scatter of the next). At a limit, above all of these: compound 4.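

The aromatic-to-saturated ring swap does not carry a fixed cost in this assay: on a saturated chain carbon it gave a 3.1-fold higher number from compound 1 to compound 2 (0.49 log units; beyond the scatter), but on an amine nitrogen in a ring it gave an at least 370-fold higher number from compound 3 to compound 4 (2.57 log units; beyond the scatter). So the effect of this swap depends on where the group is attached and what it is attached through, which compounds 1 and 2 alone could not show. For compound 4 the value is a limit of the assay and not a number, so only the lowest possible size of this step is known: the limit of > 20000 nM in this assay, at which 1 of the 4 values shown sits.

The change also removes the one-carbon link of the benzyl group, so the compounds shown leave open whether the saturated ring or the shorter connection accounts for the loss. A 4-(hydroxycarbamoyl)cyclohexylmethyl group on the same ring nitrogen would keep that carbon link with the saturated ring and so separate the two.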